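The source may report more compounds than this note shows. Statements on the series, on what has been measured and on what is new or still open speak of the compounds shown alone.

Compounds measured so far:
- compound 1, `O=C(O)Cc1sc(C(c2ccc(F)cc2)c2ccc(F)cc2)nc1-c1ccoc1`, 80%
- compound 2, `O=C(O)Cc1sc(C(c2ccc(F)cc2)c2ccc(F)cc2)nc1-c1cccc(F)c1`, 80%

Both values come from an in vitro functional assay on HEK285-7 cells for antagonist activity at prostaglandin D2 receptor 2 (Homo sapiens), read by BRET and beta-arrestin recruitment; a higher number here means a larger maximal response, a lower number a smaller maximal response. Compound 2 stands level with compound 1 at the digits shown; the only measured step, no change at the digits printed from compound 1 to compound 2 (within the scatter), lies within the scatter of repeated runs. The next compound, compound 3, `Cc1cc(-c2nc(C(c3ccc(F)cc3)c3ccc(F)cc3)sc2CC(=O)O)cnc1N`, differs from compound 2 in one place: 6-amino-5-methylpyridin-3-yl in place of 3-fluorophenyl on an aromatic carbon. For the measured compounds named here, no measured pair changes this position in the same way, so the expectation rests on the single step from compound 1 to compound 2, in which one aromatic ring replaced another at the same place without any shift beyond the scatter. The step in this assay from compound 2 to compound 3 is therefore expected to be small, no change at the digits printed from compound 2 to compound 3 (within the scatter), with no clear direction. For compound 3 the estimated value in this assay is 80%, expected to fall between 60% and 95%.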

Compound 3, largest response reached (reported as efficacy), in percent of the reference or control that the assay uses: 80%
The estimate for compound 3 equals the measured number at the digits printed, and the stated range covers the measured number.
By their numbers in this assay, from the lowest: compounds 1, 2 and 3 (each within the scatter of the next).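

At this position, next to the ring nitrogen, a change larger than the earlier one still leaves the read-out unmoved: in this assay, 6-amino-5-methylpyridin-3-yl in place of 3-fluorophenyl gives no change at the digits printed from compound 2 to compound 3 (within the scatter). The entering ring brings a hydrogen-bond donor and acceptors, whereas 3-fluorophenyl has neither, and the comparison with furan-3-yl gives no change at the digits printed from compound 1 to compound 3 (within the scatter), so all three aromatic rings stand level here. Nothing available explains this lack of change.

As far as these compounds go, all three compounds carry an aromatic ring at this place, so the outcome with a methyl group, a cyclohexyl ring or a longer alkyl chain stays open. Also open, from the compounds shown here alone, is whether the same holds when the carboxymethyl group is swapped for an amide.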